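From 4-Methylpiperazin-1-yl to Sulfamoyl: an Unreadable Step

The source may report more compounds than this note shows. Statements on the series, on what has been measured and on what is new or still open speak of the compounds shown alone.

Measured so far in a functional assay on MCF7 cells (Homo sapiens) for antiproliferative activity, read by MTT assay; on this read-out higher numbers stand for weaker inhibition and lower numbers for stronger inhibition:
Compound 1 `CN1CCN(c2ccc(Nc3ncc(/N=C/c4ccccc4)c(NC4CCCC4)n3)cc2)CC1`: > 100000 nM
Compound 2 `CC(C)Nc1nc(Nc2ccc(N3CCN(C)CC3)cc2)ncc1/N=C/c1ccccc1`: > 100000 nM
Compound 3 `CC(C)Nc1nc(Nc2ccc(N3CCN(C)CC3)cc2)ncc1/N=C/c1ccc(C(F)(F)F)cc1`: > 100000 nM

Compound 2 stands at a limit of this assay rather than at a measured number. The same is true of every compound measured here, as shown by the limit of > 100000 nM in this assay, at which 3 of the 3 values shown sit. Two single-point changes connect these compounds. Replacing cyclopentyl with isopropyl on a ring nitrogen gives a step that the two limits leave unreadable from compound 1 to compound 2. Adding trifluoromethyl to an aromatic carbon gives a step that the two limits leave unreadable from compound 2 to compound 3. Neither step can be read, because both ends sit at the limit, so neither tells how far a new change might move the value.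

Compound 4 `CC(C)Nc1nc(Nc2ccc(S(N)(=O)=O)cc2)ncc1/N=C/c1ccccc1` is not yet measured. It differs from compound 2 by sulfamoyl in place of 4-methylpiperazin-1-yl on an aromatic carbon. Within the data shown here, no measured step touches this part of the molecule, and the steps that do exist are unreadable, so there is no basis in these data for expecting a move beyond the scatter in either direction. For compound 4 the expected step is a number no higher from compound 2 to compound 4 (the limit leaves the size open). Compound 4 is therefore estimated at 100000 nM, with a range from 20000 nM to 300000 nM, and most likely the assay will again report only a limit.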

Compound 4, half-maximal inhibitory concentration: > 100000 nM
Compound 4 was reported as a limit (the forecaster's own chance of this, stated with the estimate: 70%); the middle value lies on the limit itself.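

Compound 4, like compound 2, is reported only as a limit, so the step between them cannot be read, and neither can the earlier steps: the limit of > 100000 nM in this assay, at which 4 of the 4 values shown sit.

The compounds shown leave open how far any of these changes moves the value in this assay, and which change to the shared core would give a measured number.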